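The source may report more compounds than this note shows. Statements on the series, on what has been measured and on what is new or still open speak of the compounds shown alone.

The series shares one core; compound 1 is `Nc1nc2ccc(C(F)(F)C(F)(F)F)cc2s1` and compound 2 is `N=c1sc2cc(OC(F)(F)F)ccc2n1CC(N)=O`. For the measured compounds named here, in a functional assay on the whole organism with Rattus norvegicus as the target (a higher number here means that more compound is needed for the effect, a lower number that less compound is needed), compound 1 gives 2.5 mg/kg, while compound 2 gives 7 mg/kg, the highest of the two numbers known so far; the gap to compound 1 lies beyond the usual scatter. Compound 3, `CN(C)CCCn1c(=N)sc2cc(OC(F)(F)F)ccc21`, has not yet been measured in this assay. Compared with compound 2 it carries 2-(dimethylamino)ethyl in place of carbamoyl on a saturated chain carbon bound to an aromatic nitrogen. Going by the values given here, no measured pair isolates this change, and compounds 1 and 2 differ in more than one place, so their two values show only that compound 2 needs the larger dose. The estimated step of a 1.4-fold lower number from compound 2 to compound 3 (0.15 log units; within the scatter) is expected to stay within the usual scatter, with no firm direction. Compound 3 is therefore estimated at 5 mg/kg in this assay, with a range from 1.5 mg/kg to 15 mg/kg.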

Compound 3, dose for half-maximal effect: 9 mg/kg
For compound 3 the middle estimate is 1.8-fold (0.26 log units) below the measured one, and the stated range covers the measured number.
By their numbers in this assay, from the lowest: compound 1; then compounds 2 and 3 (each within the scatter of the next).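

For the compounds shown here, at the saturated chain carbon bound to an aromatic nitrogen, 2-(dimethylamino)ethyl in place of carbamoyl gives in this assay a 1.3-fold higher number from compound 2 to compound 3 (0.11 log units; within the scatter), the first step that isolates one place. Read with its longer form, carbamoylmethyl to 3-(dimethylamino)propyl, this pair shows that the chain can lose the carbonyl and the amide hydrogens and gain carbon atoms while compound 2 and compound 3 stay within the scatter of each other. Nothing measured here gives a reason for this result.

Still open, as far as these compounds go, is whether a carboxylic acid, a morpholine or a shorter chain ending in a primary amine at this place would also stay within the scatter. The gap separating compound 1 from the other two also remains unassigned, as the compounds shown hold no pair linking it to a single place.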